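Side-group swap from compound 2 to compound 4

The compounds below may be only part of what the source reports. "The series", "measured", "known", "first", "only" and "open" are said of these compounds alone.

Within the data shown here, in a functional assay on a cell-free system (plasma, Homo sapiens), with a stated time of 3 min (a higher number here means a weaker inhibitor, a lower number a stronger inhibitor), three compounds have numbers so far. Compound 1 `O=C(NCc1cc(Cl)ccc1-n1cnnn1)[C@@H]1CC=NN1C(=O)[C@H](O)Cc1ccccc1` gives 1400 nM, compound 2 `COC(C)(C)[C@@H](O)C(=O)N1C[C@H]2C[C@H]2[C@H]1C(=O)NCc1cc(Cl)ccc1-n1cnnn1` gives 1000 nM, and compound 3 `CC(C)(C)C[C@@H](O)C(=O)N1CC[C@@H]2C[C@@]21C(=O)NCc1cc(Cl)ccc1-n1cnnn1` gives 620 nM. Compound 2 thus stands in the interior of this small set, within the scatter of both compound 1 and compound 3.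

Compound 4 `O=C(NCc1cc(Cl)ccc1-n1cnnn1)[C@@H]1[C@@H]2C[C@@H]2CN1C(=O)[C@H](O)c1ccccc1F` is not yet measured. It keeps the shared core of compound 2 and carries 2-fluorophenyl in place of 1-methoxy-1-methylethyl on a saturated chain carbon bound to a carbonyl carbon and an oxygen on a saturated carbon.

Among the measured compounds shown here, the series offers no measured pair that differs in one place only, so the size of this swap in this assay cannot be read directly from the data. For the measured compounds named here, the only guide is the general range: compound 1, which has an aromatic ring in its side group, gives 1400 nM, and compound 3, which has none, gives 620 nM. On that basis, a large change is not expected. The estimate is a 1.7-fold lower number from compound 2 to compound 4 (0.22 log units; within the scatter), a modest move towards a lower number and no shift beyond the scatter. For compound 4 the expected value is 600 nM, with an estimated range of 150 nM to 2000 nM.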

Compound 4, half-maximal inhibitory concentration: 580 nM
For compound 4 the middle estimate is 1.0-fold (0.01 log units) above the measured one, within the range that was stated.
By their numbers in this assay, from the lowest: compounds 4, 3, 2 and 1 (each within the scatter of the next, the first and the last beyond it).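

In this assay, the saturated chain carbon bound to a carbonyl carbon and an oxygen on a saturated carbon now has its first reading from a change in one place: 2-fluorophenyl in place of 1-methoxy-1-methylethyl gives a 1.7-fold lower number from compound 2 to compound 4 (0.24 log units; within the scatter) on the shared core of compound 2. This position therefore takes one six-membered aromatic ring of carbon only where a group with no ring stood, with no shift beyond the scatter, even though the hydrogen-bond acceptor of the leaving group is gone and the heavy-atom count differs. Nothing measured in this set bears on why the two groups read so alike.

Open, going by these compounds, is how a plain phenyl, an amine or a carboxylic acid at this place would read in this assay on the core of compound 2, and so whether the fluorine or the ring carries any weight and whether a charged group is taken as readily. Also open, on these data alone, is whether this tolerance holds on the cores of compound 1 and compound 3, which differ from compound 4 in more than one place, so steps to them cannot be read.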